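The source may hold more compounds than are shown below. What is called first, only, known or untested is meant among the compounds shown, and "the series" means these compounds.

Measured in an ADME assay on HeLa cells (Homo sapiens) for cytotoxicity, read by crystal violet staining, with a stated time of 72 h; a higher number here means that more compound is tolerated, a lower number that less compound is tolerated:
Compound 1 (`CCOC(=O)c1cc(CCCOc2c(C)cc(-c3noc(C(F)(F)F)n3)cc2C)on1`): 17200 nM
Compound 2 (`COc1ccc(-c2cc(CCCOc3c(C)cc(-c4noc(C(F)(F)F)n4)cc3C)on2)cc1OC`): 41900 nM

For the measured compounds named here, of these two numbers, the one for compound 2 is the higher, so more of it is tolerated. Going by the values given here, the only measured step is a 2.4-fold higher number from compound 1 to compound 2 (0.39 log units; beyond the scatter). It came from putting 3,4-dimethoxyphenyl in place of ethoxycarbonyl on an aromatic carbon.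

Compound 3 (`Cc1cc(-c2noc(C(F)(F)F)n2)cc(C)c1OCCCc1cc(C(N)=O)no1`) keeps the shared core and changes that same carbon again: carbamoyl in place of 3,4-dimethoxyphenyl on an aromatic carbon. Carbamoyl now stands in place of 3,4-dimethoxyphenyl, so the large aromatic group is gone, as it is in compound 1. Carbamoyl is not ethoxycarbonyl, though, and no measured compound carries it, so this single step is only a rough guide. In this assay, part of the earlier rise is expected to be lost, which would move the number back towards compound 1 at 17200 nM. The expected step is a 1.6-fold lower number from compound 2 to compound 3 (0.19 log units; within the scatter). For compound 3 the estimate is 27000 nM, with an expected range from 9000 nM to 90000 nM.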

Compound 3, half-maximal cytotoxic concentration: > 100000 nM
Compound 3 was reported as a limit; the forecaster's own chance of this, stated with the estimate: 15%; at least 3.7-fold (0.56 log units) between middle value and limit.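

In this assay compound 3 gives no exact number, only a limit: the limit of > 100000 nM in this assay, at which 1 of the 3 values shown sits.

Even read as a limit, the result shows that this carbon of the shared core can shift the number further than the first pair revealed, with an at least 2.3-fold higher number from compound 2 to compound 3 (0.37 log units; beyond the scatter) for carbamoyl in place of 3,4-dimethoxyphenyl, and an at least 5.8-fold higher number from compound 1 to compound 3 (0.76 log units; beyond the scatter) for amino in place of ethoxy on the carbonyl carbon. The second step is the more telling one, since only the group on the carbonyl carbon differs, and the number still moves beyond the scatter. The number also does not simply follow group size: 3,4-dimethoxyphenyl, with 10 heavy atoms, already stood above ethoxycarbonyl, yet carbamoyl, with 3 heavy atoms, stands above both.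

As far as these compounds go, how far compound 3 really lies above the other two stays unknown, so both steps give only a lower bound on the true size of the change. The compounds shown also cannot tell whether the amide hydrogen matters or whether any small group on this carbon would do the same, a question that a nitrile or a carboxylic acid at that place would bear on.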